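Dimethoxyphenyl to Dihydroxyphenyl on a Shared Benzothiazole Amide Core

The source may hold more compounds than are shown below. What is called first, only, known or untested is meant among the compounds shown, and "the series" means these compounds.

Measured compounds:
- compound 1 `COc1ccc(/C=N/NC(=O)c2ccc(-c3nc4ccccc4s3)cc2)cc1OC`: "not active" (no number reported)
- compound 2 `COc1ccc(/C=N/NC(=O)c2ccc(-c3nc4ccccc4s3)cc2)cc1O`: "not active" (no number reported)
- compound 3 `O=C(N/N=C/c1ccccc1)c1ccc(-c2nc3ccccc3s2)cc1`: 8050 nM

In an assay on isolated protein for inhibition of Maltase-glucoamylase (Homo sapiens), with a stated time of 15 min (on this read-out higher numbers stand for weaker inhibition and lower numbers for stronger inhibition), compound 1 gives "not active" (no number reported), so no number stands for it. Compound 2 likewise gives "not active" (no number reported) in this assay. Only compound 3 gives a number, and in this assay compound 3 gives 8050 nM, a weak inhibition. Compound 4 `O=C(N/N=C/c1cc(O)ccc1O)c1ccc(-c2nc3ccccc3s2)cc1` is the next step from compound 1, and it differs by 2,5-dihydroxyphenyl in place of 3,4-dimethoxyphenyl on a carbon with a double bond to nitrogen. Within the data shown here, no step between two measured compounds exists here, so there is no measured change to lean on. Any step from compound 1 to compound 4 in this assay cannot be sized from a starting number, since compound 1 has none; the expectation is at most a small gain, toward weak but measurable inhibition, rather than anything beyond the scatter of the numbers seen. Compound 4 is expected to give about 12000 nM in this assay, within a range from 4000 nM to 40000 nM, because compound 3 gives 8050 nM and the shared core has shown no stronger inhibition than that.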

Compound 4, half-maximal inhibitory concentration: 11900 nM
Estimate against measurement, compound 4: 1.0-fold (0.00 log units) above; the range from low to high includes it.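

In this assay, this position, on a carbon with a double bond to nitrogen, now gives its first readable comparison: a 1.5-fold higher number from compound 3 to compound 4 (0.17 log units; within the scatter), with 2,5-dihydroxyphenyl in place of phenyl. These two groups therefore cannot be told apart in this assay, whereas compound 1, with 3,4-dimethoxyphenyl at the same place, gives "not active" (no number reported), so any step from it, or from compound 2, cannot be read as a size. Nothing shown gives a cause for these results.

On these data alone, what stays open is whether a different group on the phenyl ring at this place, such as an amine or a carboxylic acid, would move the number beyond the usual scatter. As far as these compounds go, it is also open whether a single hydroxy group on the phenyl ring, without a methoxy group, would give a measurable number.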